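The source may hold more compounds than are shown below. What is called first, only, known or untested is meant among the compounds shown, and "the series" means these compounds.

Compound 1 `CC(C)N1CCN(Cc2csc(N)c2C(=O)c2ccc(Cl)cc2)CC1` carries the shared core with an isopropyl group on an amine nitrogen in a ring. For the measured compounds named here, in a functional assay on CHO cells with adenosine receptor A1 (Homo sapiens) as the target, read by cAMP accumulation and immunoassay, with a stated time of 6 min, tested at 1 uM (a lower number here means a stronger effect, a higher number a weaker effect of the compound at the concentration tested), compound 1 gives 7.3%, the highest of the three numbers measured so far. Compound 2 `COc1ccc(N2CCN(Cc3csc(N)c3C(=O)c3ccc(Cl)cc3)CC2)cc1`, where a 4-methoxyphenyl sits in the same place, gives -15% in this assay; the step is a number 22.3 percentage points lower from compound 1 to compound 2 (beyond the scatter). Compound 3 `Nc1scc(CN2CCN(c3cccc(F)c3)CC2)c1C(=O)c1ccc(Cl)cc1`, with a 3-fluorophenyl there, gives -86% in this assay; from compound 1 this is a number 93.3 percentage points lower from compound 1 to compound 3 (beyond the scatter), and from compound 2 it is a number 71 percentage points lower from compound 2 to compound 3 (beyond the scatter). The unmeasured compound 4 `Nc1scc(CN2CCN(c3ccc(F)c(F)c3)CC2)c1C(=O)c1ccc(Cl)cc1` differs from compound 1 as follows: 3,4-difluorophenyl in place of isopropyl on an amine nitrogen in a ring. The step from compound 1 to compound 3 bears most on this change, since 3,4-difluorophenyl is closest in kind to 3-fluorophenyl, and the step from compound 1 to compound 2 shows that the other aryl group also lowered the number, though by less. A large downward step is therefore expected, estimated as a number 87.3 percentage points lower from compound 1 to compound 4 (beyond the scatter). Compound 4 is expected to give about -80% in this assay, between -115% and -35%.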

Compound 4, a percentage reported as activity, at one concentration (the size of the read-out at that concentration, not a potency): -78%
For compound 4 the middle estimate is 2 percentage points below the measured one, within the range that was stated.
By their numbers in this assay, from the lowest: compounds 3 and 4 (each within the scatter of the next); then compound 2; then compound 1.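

In this assay, a fluoro in place of hydrogen on the aromatic ring of compound 3 gives a result that cannot be told apart from it: the step is a number 8 percentage points higher from compound 3 to compound 4 (within the scatter). The low number therefore holds with a second fluoro on the ring, as the step of a number 85.3 percentage points lower from compound 1 to compound 4 (beyond the scatter) shows against isopropyl and the step of a number 63 percentage points lower from compound 2 to compound 4 (beyond the scatter) shows against 4-methoxyphenyl. Nothing shown here explains these numbers.

The compounds shown leave open whether any fluoro is needed, since a plain phenyl on that ring nitrogen would test this directly. They also leave open how a chlorophenyl, a pyridine ring or a cyclohexyl in the same place would compare.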